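A few compounds are considered here, and "the series" means these few. Any claim that something is new, unique, unknown or untested is made for them only; others in the source may bear on it.

Compound 1 `Cc1ccc(COc2ccc(-c3cc(CN4CCN(Cc5ccc(C(F)(F)F)cc5)CC4)no3)cc2)cc1` is one of three close relatives tested in a functional assay on Huh-7 cells (Homo sapiens) for antiproliferative activity, read by sulforhodamine B assay, with a stated time of 72 h (a higher number here means a weaker inhibitor, a lower number a stronger inhibitor), where compound 1 gives 1500 nM. Compound 2 `FC(F)(F)c1ccc(CN2CCN(Cc3cc(-c4ccc(OCc5ccc(Cl)cc5)cc4)on3)CC2)cc1` gives 4000 nM, while compound 3 `Fc1ccccc1COc1ccc(-c2cc(CN3CCN(Cc4ccc(C(F)(F)F)cc4)CC3)no2)cc1` gives 1500 nM. For the measured compounds named here, compound 1 therefore stands level with compound 3 at the lowest number of the three, and only the step of a 2.7-fold higher number from compound 1 to compound 2 (0.43 log units; beyond the scatter) separates it from the rest. The new compound 4 `COc1cc(COc2ccc(-c3cc(CN4CCN(Cc5ccc(C(F)(F)F)cc5)CC4)no3)cc2)cc(OC)c1OC` differs from compound 1 in one place: 3,4,5-trimethoxyphenyl in place of 4-methylphenyl on a saturated chain carbon bound to an oxygen on an aromatic ring. Two earlier swaps at that same saturated chain carbon bear on this, no change at the digits printed from compound 1 to compound 3 (within the scatter) and a 2.7-fold lower number from compound 2 to compound 3 (0.43 log units; beyond the scatter), and both were small. A similarly small step is expected here, no change at the digits printed from compound 1 to compound 4 (within the scatter). Compound 4 is thus estimated at 1500 nM, within a range from 500 nM to 4500 nM.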

Compound 4, half-maximal inhibitory concentration: 500 nM
For compound 4 the middle estimate is 3.0-fold (0.48 log units) above the measured one; measured number inside the range.
By their numbers in this assay, from the lowest: compound 4; then compounds 1 and 3 (each within the scatter of the next); then compound 2.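

At this position, 3,4,5-trimethoxyphenyl produces a shift beyond the scatter in this assay, with a 3.0-fold lower number from compound 1 to compound 4 (0.48 log units; beyond the scatter) and a 3.0-fold lower number from compound 3 to compound 4 (0.48 log units; beyond the scatter), whereas 2-fluorophenyl and 4-methylphenyl gave the same number. Against the 4-chlorophenyl of compound 2 there is an 8.0-fold lower number from compound 2 to compound 4 (0.90 log units; beyond the scatter), the widest step yet seen at this carbon. Nothing measured here explains why this group lowers the number.

As far as these compounds go, whether a single methoxy group on the phenyl ring would do the same remains open. So does the effect of a dimethylamino group or a carboxylic acid there.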